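Shortening the chain on a shared core

A few compounds are considered here, and "the series" means these few. Any claim that something is new, unique, unknown or untested is made for them only; others in the source may bear on it.

Measured so far:
- compound 1, `COc1cccc(-c2nn3cc(-c4cccc(N)c4)nc3s2)c1`, gives 29000 nM in a functional assay on FM3A cells (Mus musculus) for inhibition, read by cell counting, with a stated time of 2 days; on this read-out lower numbers stand for stronger inhibition and higher numbers for weaker inhibition
- compound 2, `C=C(Br)C(=O)Nc1cccc(-c2cn3nc(CCc4ccccc4)sc3n2)c1`, gives 2600 nM in this assay

Compound 2 has the lowest number of the two, and the gap between compound 2 and compound 1 lies beyond the usual scatter. The two compounds differ in several places at once, so the readings say nothing about any single change between them.

Compound 3, `C=C(Br)C(=O)Nc1cccc(-c2cn3nc(Cc4ccccc4)sc3n2)c1`, keeps everything in compound 2 except one change: phenyl in place of benzyl on a saturated chain carbon bound to an aromatic carbon. The same difference, cut one bond further out, reads phenethyl to benzyl. Among the measured compounds shown here, no measured pair shows this change on this core, so there is nothing to lean on. The expected outcome is a step from compound 2 to compound 3 of a 1.2-fold higher number from compound 2 to compound 3 (0.06 log units; within the scatter) in this assay, that is, no shift beyond the scatter. Compound 3 is therefore estimated at 3000 nM in this assay, within a range of 1000 nM to 9000 nM.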

Compound 3, half-maximal inhibitory concentration: 3000 nM
Compound 3: the middle estimate sits on the measured number at the digits printed; measured number inside the range.
By their numbers in this assay, from the lowest: compounds 2 and 3 (each within the scatter of the next); then compound 1.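

Among the compounds shown here, compound 3 gives the first reading of a single change on the shared core: in this assay, phenyl in place of benzyl on a saturated chain carbon bound to an aromatic carbon gives a 1.2-fold higher number from compound 2 to compound 3 (0.06 log units; within the scatter). On this one pair, then, shortening the chain from phenethyl to benzyl does not separate the two compounds, and the change in the chain alone cannot account for the gap that compound 1 shows to either of them. No measurement at hand bears on why these two readings stay so close.

As far as these compounds go, whether the readings would stay as close with a longer chain such as phenylpropyl, or with an amine or a carboxylic acid at the end of the chain, remains open. From the compounds shown here alone, compound 1 and compound 2 still differ in several places at once, and the separate effect of each difference is also open.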